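The source may report more compounds than this note shows. Statements on the series, on what has been measured and on what is new or still open speak of the compounds shown alone.

Measured so far in an assay on isolated protein for agonist activity at Bile acid receptor (Homo sapiens), read by FRET; a lower number here means that less compound is needed, a higher number that more compound is needed for the effect:

Compound 1 `O=C(O)c1cccc([C@H]2C[C@@H](c3ccc(OCc4c(-c5c(Cl)cccc5Cl)noc4C4CC4)cc3Cl)C2)c1` — compound 1 gives 77 nM.
Compound 2 `O=C(O)CNC(=O)c1ccc(C2CC2c2ccc(OCc3c(-c4c(Cl)cccc4Cl)noc3C3CC3)cc2Cl)cc1` — compound 2 gives 150 nM.
Compound 3 `O=C(O)c1cccc(C2CC2c2ccc(OCc3c(-c4c(Cl)cccc4Cl)noc3C3CC3)cc2Cl)c1` — compound 3 gives 32 nM.

Compound 3 stands lowest of the three numbers in this assay. Its nearest neighbour is compound 1, whose number is higher by a margin beyond the usual scatter; compound 2 lies furthest from it, also beyond the scatter. Compounds 1 and 3 share the same acid-bearing aryl group on different saturated rings, and compound 2 carries a glycine amide instead of the free acid; none of these pairs differ in one place only, so their values are noted without a computed step.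

The next compound, compound 4 `CC(C)n1nc(C(=O)O)cc1C1CC1c1ccc(OCc2c(-c3c(Cl)cccc3Cl)noc2C2CC2)cc1Cl`, keeps the core of compound 3 and changes the acid-bearing group: 3-carboxy-1-isopropyl-1H-pyrazol-5-yl in place of 3-carboxyphenyl on a saturated ring carbon. Going by the values given here, no step between measured compounds covers a change of this kind, so the expectation rests on the number for compound 3 alone. A modest step in this assay is expected, more likely toward a higher number than a lower one, with a fair chance that it stays within the scatter. Compound 4 is therefore estimated at 60 nM, with a range from 15 nM to 250 nM, which means an expected step of a 1.9-fold higher number from compound 3 to compound 4 (0.27 log units; within the scatter).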

Compound 4, half-maximal effective concentration in the Bile acid receptor assay: 7 nM
Estimate against measurement, compound 4: 8.6-fold (0.93 log units) above; the whole stated range lies above it.
By their numbers in the Bile acid receptor assay, from the lowest: compound 4; then compound 3; then compounds 1 and 2 (each within the scatter of the next).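

On the saturated ring carbon of the three-membered ring, activity in the Bile acid receptor assay does not depend on a six-membered aromatic ring of carbon only: with 3-carboxy-1-isopropyl-1H-pyrazol-5-yl in place of 3-carboxyphenyl, the series shows a 4.6-fold lower number from compound 3 to compound 4 (0.66 log units; beyond the scatter). Going by these compounds alone, all the earlier compounds carry the acid-bearing group on a carbon-only aromatic ring, so this is the first sign that a five-membered aromatic ring with 2 hetero atoms is accepted here. The gain in this pair does not come at a cost in a physicochemical assay for solubility (a higher number here means a more soluble compound, a lower number a less soluble compound), where compound 3 gives 20000 nM and compound 4 gives 158000 nM and the same exchange also moves in the favourable direction: the measured solubility of compound 3, 20000 nM, and of compound 4, 158000 nM, a 7.9-fold higher number (0.90 log units; beyond the scatter)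

The isopropyl group and the new ring enter together in this single pair, so their separate shares in either step remain unresolved. Open questions are whether a methyl group or a plain hydrogen in place of the isopropyl retains the number in the Bile acid receptor assay, and whether a primary amide can stand in for the carboxylic acid on this ring.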